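This account rests on a few compounds, and the source may have more. Where it says the series, first, only, none or still open, it means among the compounds named here.

Working notes on the series. In a functional assay on A549 cells (Homo sapiens) for antiproliferative activity, read by MTT assay, with a stated time of 72 h (on this read-out higher numbers stand for weaker inhibition and lower numbers for stronger inhibition), compound 1 `COc1cc2c(Nc3ccc(C#N)cc3)ncnc2cc1OCCCN1CCc2ccccc2C1` reads > 100000 nM, which is a limit and not a number. For the measured compounds named here, compound 2 `COc1cc2c(Nc3ccc(C#N)cc3)ncnc2cc1OCCCN1CCC(N(C)C)CC1` gives 42400 nM, the only actual number so far. Going by the values given here, the one measured step, at the same place, is an at least 2.3-fold lower number from compound 1 to compound 2 (0.37 log units; beyond the scatter). Compound 3 `CCN1CCN(CCCOc2cc3ncnc(Nc4ccc(C#N)cc4)c3cc2OC)CC1` differs from compound 2 by 4-ethylpiperazin-1-yl in place of 4-(dimethylamino)piperidin-1-yl on a saturated chain carbon, three bonds along the chain from an oxygen on an aromatic ring, on a saturated chain carbon, three bonds along the chain from an oxygen on an aromatic ring. Among the compounds with values here, with only that step as a guide, and its size open-ended, no shift beyond the scatter is expected in this assay. The expected step is a 1.1-fold higher number from compound 2 to compound 3 (0.03 log units; within the scatter). For compound 3 the estimate is 45000 nM, with an expected range of 15000 nM to 100000 nM.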

Compound 3, half-maximal inhibitory concentration: 16000 nM
Estimate against measurement, compound 3: 2.8-fold (0.45 log units) above, within the range that was stated.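

In this assay, 4-ethylpiperazin-1-yl in place of 4-(dimethylamino)piperidin-1-yl gives a 2.7-fold lower number from compound 2 to compound 3 (0.42 log units; beyond the scatter), so this position responds even to a change between groups with the same counts of hydrogen-bond donors and acceptors. In place of 1,2,3,4-tetrahydroisoquinolin-2-yl, the same group gives an at least 6.2-fold lower number from compound 1 to compound 3 (0.79 log units; beyond the scatter), an open-ended step. Compound 1 stands as a limit and not a number: the limit of > 100000 nM in this assay, at which 1 of the 3 values shown sits.

Open, on these data alone, is whether morpholine or unsubstituted piperazine at this place would lower the number further. Also open, as far as these compounds go, is how a longer chain would read.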